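A few compounds are considered here, and "the series" means these few. Any claim that something is new, unique, unknown or untested is made for them only; others in the source may bear on it.

Among the compounds with values here, in a functional assay on HepG2 cells (Homo sapiens) for antiproliferative activity, read by MTT assay, with a stated time of 48 h (a lower number here means a stronger inhibitor, a higher number a weaker inhibitor), compound 2 `COc1ccc(N(C)c2cc(C)nc(C)n2)cc1Cl` gives 787 nM, the lower of the two numbers so far, while compound 1 `COc1ccc(N(C)c2cc(C)nc(C)n2)cc1F` gives 2060 nM. Compound 3 `COc1ccc(N(C)c2cc(C)nc(C)n2)cc1[N+](=O)[O-]` has nitro in place of chloro on an aromatic carbon, ortho to a methoxy group: nitro in place of chloro on an aromatic carbon. Within the data shown here, only one measured step bears on this change, a 2.6-fold lower number from compound 1 to compound 2 (0.42 log units; beyond the scatter), with chloro in place of fluoro, and it was modest. That step involves no nitro, so it points to no clear direction, and a small change is expected: a 1.3-fold lower number from compound 2 to compound 3 (0.12 log units; within the scatter). For compound 3 the estimated value is 600 nM, with an expected range of 150 nM to 2400 nM.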

Compound 3, half-maximal inhibitory concentration: 2990 nM
Compound 3: middle estimate off by 5.0-fold (0.70 log units), on the low side; measured number above the stated range.
By their numbers in this assay, from the lowest: compound 2; then compounds 1 and 3 (each within the scatter of the next).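

In this assay, putting nitro in place of chloro, ortho to a methoxy group, gives a 3.8-fold higher number from compound 2 to compound 3 (0.58 log units; beyond the scatter), so the lower number seen with chloro does not carry over to nitro. Set against fluoro, nitro gives a 1.5-fold higher number from compound 1 to compound 3 (0.16 log units; within the scatter), which leaves chloro as the only one of the three groups that stands apart, with the lowest number. No measured evidence accounts for this difference. The compounds shown leave open how bromo, methyl or an amine at this position would compare with chloro. They also leave open whether chloro keeps its lead when the methoxy group is replaced by a longer chain.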